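The source may hold more compounds than are shown below. What is called first, only, known or untested is meant among the compounds shown, and "the series" means these compounds.

The series shares the core seen in compound 1 `O=C(CCc1ccncc1)C(Nc1ccccc1Cl)c1ccccc1Br` and compound 2 `Cc1ccc(NC(C(=O)CCc2cccnc2)c2ccccc2Br)c(Cl)c1`. In an assay on isolated protein for binding affinity to corticotropin-releasing factor receptor 1 (Homo sapiens) (a higher number here means a weaker inhibitor, a lower number a stronger inhibitor), compound 1 gives 7330 nM. For compound 2 this assay reports only a limit, > 10000 nM. Compound 2 therefore stands at the limit of > 10000 nM in this assay, at which 1 of the 2 values shown sits. For the measured compounds named here, no step between two measured compounds is available, so the two values are noted only as they stand. Compound 3 `Cc1ccc(NC(C(=O)CCc2ccc(F)cc2)c2ccccc2Br)c(Cl)c1` has not yet been measured in this assay. It differs from compound 2 by 4-fluorophenyl in place of pyridin-3-yl on a saturated chain carbon, two bonds along the chain from a carbonyl carbon. Nothing measured here shows how such a change reads in this assay, so no step beyond the usual scatter is expected in either direction. The expected step is an at least 1.2-fold lower number from compound 2 to compound 3 (0.09 log units; that floor lies within the scatter). Compound 3 is estimated to give 8000 nM in this assay, with a range of 2500 nM to 25000 nM.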

Compound 3, inhibition constant: > 10000 nM
Compound 3 ended at the assay's limit; the forecaster's own chance of this, stated with the estimate: 40%; at least 1.2-fold (0.09 log units) between middle value and limit.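

Compound 2 and compound 3 both stand only as limits in this assay, so no step can be read between them: the limit of > 10000 nM in this assay, at which 2 of the 3 values shown sit. The compounds shown leave open whether 4-fluorophenyl in place of pyridin-3-yl shifts the value at all.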